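Replacing 2-methoxyphenyl with 3-cyanophenyl in compound 4

The source may report more compounds than this note shows. Statements on the series, on what has been measured and on what is new or still open speak of the compounds shown alone.

These compounds share one core and differ in the aryl group on a saturated chain carbon bound to an aromatic nitrogen. In a toxicity assay on NIH3T3 cells (Mus musculus) for cytotoxicity, read by resazurin assay (a higher number here means that more compound is needed for the effect, a lower number that less compound is needed), compound 3 (`COC(=O)c1ccc(NCc2cncn2Cc2ccccc2OC)cc1-c1ccccc1`) offers no number, its entry reading "not determined" (no result reported). Compound 4 (`COC(=O)c1ccc(NCc2cncn2Cc2cccc(C#N)c2)cc1-c1ccccc1`) carries 3-cyanophenyl in place of 2-methoxyphenyl on a saturated chain carbon bound to an aromatic nitrogen. Among the compounds with values here, two bromine-bearing relatives give the only guidance. Compound 1 (`COC(=O)c1ccc(NCc2cncn2Cc2ccccc2Br)cc1-c1ccccc1`) gives 10000 nM. Compound 2 (`COC(=O)c1ccc(NCc2cncn2Cc2ccc(Br)cc2)cc1-c1ccccc1`) gives > 10000 nM, which is a limit of the assay and not a number. Their step, a number no lower from compound 1 to compound 2 (the limit leaves the size open), has no readable size, so no step beyond the scatter is expected from this swap in this assay. Compound 4 is therefore expected near 10000 nM, within an estimated range from 4000 nM to 20000 nM.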

Compound 4, half-maximal effective concentration: > 10000 nM
Compound 4 ended at the assay's limit; the forecaster's own chance of this, stated with the estimate: 60%; the middle value lies on the limit itself.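

The position tolerates more than bromine-bearing aryl groups: in this assay, 3-cyanophenyl gives a number no lower from compound 1 to compound 4 (the limit leaves the size open). A nitrile-bearing group now sits at the same limit as a bromine-bearing one, and that value is a limit, not a number: the limit of > 10000 nM in this assay, at which 2 of the 4 values shown sit. The step between compound 2 and compound 4 cannot be read, and the change from 2-methoxyphenyl to 3-cyanophenyl has no size, as compound 3 offers no number.

Which of compound 2 and compound 4 needs more compound stays open. Also open, from the compounds shown here alone, is whether a phenyl group carrying a carboxylic acid or an amine at this place would give a readable number.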